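The source may report more compounds than this note shows. Statements on the series, on what has been measured and on what is new or still open speak of the compounds shown alone.

Three related compounds have been tested in a functional assay on PC-3 cells (Homo sapiens) for inhibition, read by sulforhodamine B assay, with a stated time of 48 h, tested at 50 uM (a higher number here means more inhibition of growth at the concentration tested, a lower number less inhibition of growth), and they offer little to compare. Compound 1 `COc1cccc(/C=C/C(=O)/C=C/c2ccc(OCc3cn(CCCCOc4cc(=O)oc5ccccc45)nn3)c(OC)c2)c1` is reported as "not active" (no number reported), and compound 3 `COc1cccc(/C=C/C(=O)/C=C/c2ccc(OCc3cn(CCCOc4cc(=O)oc5ccccc45)nn3)c(OC)c2)c1` is reported as "not active" (no number reported). Among the compounds with values here, compound 2 `COc1cccc(/C=C/C(=O)/C=C/c2ccc(OCc3cn(CCOc4cc(=O)oc5ccccc45)nn3)c(OC)c2)c1` gives 13%, the only number in the set, so it cannot be ranked against any other measured figure.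

Compound 4 `COc1ccccc1/C=C/C(=O)/C=C/c1ccc(OCc2cn(CCOc3cc(=O)oc4ccccc34)nn2)c(OC)c1`, still awaiting measurement, has the same atoms as compound 2, joined differently: 2-methoxyphenyl in place of 3-methoxyphenyl on a double-bonded chain carbon bound to a double-bonded chain carbon. Put simply, 2-methoxyphenyl stands in place of 3-methoxyphenyl on a double-bonded chain carbon bound to a double-bonded chain carbon. Within the data shown here, no measured pair in this set shows what such an exchange does, so there is no earlier step to use as a guide, and neither direction is favoured.

The expected change in this assay is therefore none beyond the usual scatter, and the estimated step is a number 1 percentage points lower from compound 2 to compound 4 (within the scatter). The expectation rests on compound 2, which gives 13%. A report without a number, of the kind seen for the other two tested compounds, would also come as no surprise. The estimate for compound 4 is 12%, with an expected range of 3% to 25%.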

Compound 4, percent growth inhibition at one concentration: 11%
Compound 4: middle estimate off by 1 percentage points, on the high side, within the range that was stated.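

In this assay, within the data shown here, putting 2-methoxyphenyl in place of 3-methoxyphenyl on a double-bonded chain carbon bound to a double-bonded chain carbon gives a number 2 percentage points lower from compound 2 to compound 4 (within the scatter), the first step in this set that can be read. The two groups have the same atoms and the same counts, and this exchange at this place does not separate compound 2 from compound 4 in this read-out, so the result gives no reason to prefer either group here. No measurement is at hand that bears on why the two compounds read alike.

As far as these compounds go, whether 4-methoxyphenyl, or a phenyl ring carrying an amine or a carboxylic acid, would give a reading clearly different from compound 2 at this place remains open, since one exchange between two closely related groups says little about the place as a whole. From the compounds shown here alone, the steps that involve compound 1 and compound 3 cannot be read, as neither has a number, so what the length of the chain joining the triazole-bearing part to the rest does to growth inhibition also remains open.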